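Shifting a trifluoromethyl group on compound 3

A few compounds are considered here, and "the series" means these few. Any claim that something is new, unique, unknown or untested is made for them only; others in the source may bear on it.

Compound 1 `CN(C(=O)NC(=O)c1ccccc1F)c1nc(C(F)(F)F)c(C(=O)N/N=C/c2ccc(C(F)(F)F)cc2)s1`: 3.97 ug/mL
Compound 2 `CN(C(=O)NC(=O)c1ccc(Cl)cc1Cl)c1nc(C(F)(F)F)c(C(=O)N/N=C/c2ccc(C(F)(F)F)cc2)s1`: 7.99 ug/mL
Compound 3 `CN(C(=O)NC(=O)c1ccc(C(F)(F)F)cc1)c1nc(C(F)(F)F)c(C(=O)N/N=C/c2ccc(C(F)(F)F)cc2)s1`: > 100 ug/mL

All three values come from a functional assay on HeLa cells (Homo sapiens) for inhibition, read by MTT assay, with a stated time of 72 h; a lower number here means a stronger inhibitor, a higher number a weaker inhibitor. For compound 3 the entry is only a limit of the assay, not a number; it sits at the limit of > 100 ug/mL in this assay, at which 1 of the 3 values shown sits, the weakest of the three. Compound 4 `CN(C(=O)NC(=O)c1cccc(C(F)(F)F)c1)c1nc(C(F)(F)F)c(C(=O)N/N=C/c2ccc(C(F)(F)F)cc2)s1` differs from compound 3 by 3-(trifluoromethyl)phenyl in place of 4-(trifluoromethyl)phenyl on a carbonyl carbon. Going by the values given here, none of the measured steps moves a trifluoromethyl group around the ring: the steps of an at least 25-fold higher number from compound 1 to compound 3 (1.40 log units; beyond the scatter) and an at least 12-fold higher number from compound 2 to compound 3 (1.09 log units; beyond the scatter) only show that 4-(trifluoromethyl)phenyl gave a limit where 2-fluorophenyl and 2,4-dichlorophenyl gave numbers. Among the compounds with values here, no step bears directly on this change, so the expected step of an at least 1.6-fold lower number from compound 3 to compound 4 (0.22 log units; that floor lies within the scatter) is uncertain. Compound 4 is estimated at 60 ug/mL, ranging from 15 ug/mL to 200 ug/mL, with a fair chance of again being reported only as a limit.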

Compound 4, half-maximal inhibitory concentration: 7.35 ug/mL
Compound 4: middle estimate off by 8.2-fold (0.91 log units), on the high side; the whole stated range lies above it.
By their numbers in this assay, from the lowest: compounds 1, 4 and 2 (each within the scatter of the next). At a limit, above all of these: compound 3.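

Moving the trifluoromethyl group on this ring, with the same atoms joined differently, changes the result sharply: an at least 13-fold lower number from compound 3 to compound 4 (1.13 log units; beyond the scatter). Compound 3 has only a limit: the limit of > 100 ug/mL in this assay, at which 1 of the 4 values shown sits. The 3-(trifluoromethyl)phenyl group instead matches the groups on the other two active compounds, with a 1.1-fold lower number from compound 2 to compound 4 (0.04 log units; within the scatter) and a 1.9-fold higher number from compound 1 to compound 4 (0.27 log units; within the scatter), so at this carbonyl carbon, the trifluoromethyl group's presence alone does not bring the loss seen with compound 3.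

Still open, as far as these compounds go, is whether that loss is specific to trifluoromethyl, or would also appear with a nitrile, an amine or a carboxylic acid in its place on 4-(trifluoromethyl)phenyl.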